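Swapping a methoxyphenyl for a naphthoyl on the sulfur chain

The source may hold more compounds than are shown below. What is called first, only, known or untested is meant among the compounds shown, and "the series" means these compounds.

Three measured compounds share one core. Compound 1 `COc1ccc(-n2c(S)nnc2-c2cc(OC)c(OC)c(OC)c2)cc1` carries a hydrogen on the sulfur; in a functional assay on HepG2 cells (Homo sapiens) for inhibition, read by MTT assay, with a stated time of 48 h (a higher number here means a weaker inhibitor, a lower number a stronger inhibitor), compound 1 gives 57500 nM. Compound 2 `CCSc1nnc(-c2cc(OC)c(OC)c(OC)c2)n1-c1ccc(OC)cc1` carries an ethyl in place of that hydrogen, and in this assay compound 2 reaches only a limit of the assay, > 60000 nM. Compound 3 `COc1ccc(CSc2nnc(-c3cc(OC)c(OC)c(OC)c3)n2-c2ccc(OC)cc2)cc1` carries a 4-methoxybenzyl on the sulfur, and in this assay compound 3 gives 41100 nM, the lowest of the two plain numbers, although the step of a 1.4-fold lower number from compound 1 to compound 3 (0.15 log units; within the scatter) lies within the scatter, as does an at least 1.4-fold lower number from compound 2 to compound 3 (0.16 log units; that floor lies within the scatter). Compound 4 `COc1ccc(-n2c(SCC(=O)c3ccc4ccccc4c3)nnc2-c2cc(OC)c(OC)c(OC)c2)cc1` is the next step along the same sulfur chain: (naphthalen-2-yl)carbonyl in place of 4-methoxyphenyl on a saturated chain carbon bound to a sulfur. The two measured steps that end at compound 3 are the ones that alter this chain, and both stayed within the scatter, so no step beyond the scatter is expected for a 1.2-fold lower number from compound 3 to compound 4 (0.07 log units; within the scatter). Compound 4 is therefore estimated at 35000 nM, with a range from 12000 nM to 90000 nM.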

Compound 4, half-maximal inhibitory concentration: > 60000 nM
Compound 4: no number, only a limit; the forecaster's own chance of this, stated with the estimate: 25%; middle value at least 1.7-fold (0.23 log units) away from the limit.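

Placing (naphthalen-2-yl)carbonyl instead of 4-methoxyphenyl on the saturated chain carbon bound to a sulfur gives an at least 1.4-fold higher number from compound 3 to compound 4 (0.16 log units; that floor lies within the scatter), so even this change, which brings a second aromatic ring and a carbonyl, yields no step readable beyond the scatter. Compound 2 and compound 4 both give limits rather than numbers, which leaves the step between them unreadable, and the results now crowd the top of the measurable range: the limit of > 60000 nM in this assay, at which 2 of the 4 values shown sit.
Among the compounds with a group on the sulfur, compound 3 alone gives a plain number, 41100 nM.

As far as these compounds go, whether any group on this sulfur can bring the number well down in this assay stays open. So does how an amine or a carboxylic acid on this chain would read, or a naphthalen-2-ylmethyl without the carbonyl.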